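The source may hold more compounds than are shown below. What is called first, only, known or untested is meant among the compounds shown, and "the series" means these compounds.

In a physicochemical assay for lipophilicity, read by HPLC, measured as chromatographic lipophilicity, at pH 7.4 (a higher number here means a more lipophilic compound, a lower number a more polar compound), compound 1 `O=C(C1CCN(c2ccccc2)CC1)N1N=CC[C@H]1c1ccccc1` gives 6.3. Compound 3 `O=C(C1CCN(c2ccccc2)CC1)N1N=CCC1c1ccccc1`, the same structure drawn without a configuration at the saturated ring carbon, gives 6.3, and compound 2 `O=C(c1ccccc1)N1CCC(C(=O)N2N=CCC2c2ccccc2)CC1` gives 4.4. Compound 1 therefore stands level with compound 3, and both lie well clear of compound 2. The only difference within the first pair is the fact that one of compounds 1 and 3 is drawn with a defined configuration and the other without, at the place where they differ, and the measured result is no change at the digits printed from compound 1 to compound 3 (within the scatter). That step offers no guide to a change of group.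

Compound 4 `O=C(C1CCN(c2ccccn2)CC1)N1N=CC[C@H]1c1ccccc1` keeps the core of compound 1 and exchanges one group: pyridin-2-yl in place of phenyl on an amine nitrogen in a ring. One measured step falls at this same place, with phenyl in place of benzoyl on an amine nitrogen in a ring, and its result is a number 1.90 log units higher from compound 2 to compound 3 (beyond the scatter). That large step shows how far the number can travel at this place, but benzoyl is not the group entering here. In compound 4 the ring stays aromatic and the heavy-atom count stays the same, while a hydrogen-bond acceptor is added. A fall is therefore expected, of clearly smaller size than the step to compound 3, and the estimated change is a number 0.80 log units lower from compound 1 to compound 4 (beyond the scatter). For compound 4 the expected value is 5.5, with an estimated range from 4.9 to 6.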

Compound 4, distribution coefficient: 5.1
For compound 4 the middle estimate is 0.40 log units above the measured one; the measured number falls inside the stated range.
By their numbers in this assay, from the lowest: compound 2; then compound 4; then compounds 1 and 3 (each within the scatter of the next).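

Pyridin-2-yl in place of phenyl on an amine nitrogen in a ring gives a number 1.20 log units lower from compound 1 to compound 4 (beyond the scatter) in this assay and is the first step measured at this place in which the ring stays aromatic and the heavy-atom count stays the same. The earlier step at this place, a number 1.90 log units higher from compound 2 to compound 3 (beyond the scatter), set phenyl against benzoyl, so a carbonyl was part of that exchange, whereas the new step shows that a large change here needs no more than one ring carbon giving way to a ring nitrogen, with the hydrogen-bond acceptor count rising accordingly. Nothing in the facts at hand, which concern only how a configuration is drawn, accounts for the size of this step.

What the compounds shown leave open is whether the number keeps falling with a pyrimidinyl group, which has a further ring nitrogen, and where it would lie with a cyclohexyl group, which has no aromatic ring at this place. They also leave open whether pyridin-2-yl gives a step of the same size on the core drawn without a configuration, as in compound 3, or with the opposite configuration at the saturated ring carbon.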